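The source may report more compounds than this note shows. Statements on the series, on what has been measured and on what is new or still open speak of the compounds shown alone.

The measured compounds:
Compound 1 `CC#CC1=Nc2ccccc2C(C)(C)O1`: in a functional assay on HCT-116 cells (Homo sapiens) for cytotoxicity, with a stated time of 3 days (on this read-out higher numbers stand for weaker inhibition and lower numbers for stronger inhibition), compound 1 gives > 40000 nM.
Compound 2 `N#Cc1nccs1`: in this assay compound 2 gives > 40000 nM.
Compound 3 `Cn1cnc2ccccc21`: in this assay compound 3 gives > 40000 nM.

Compound 1 stands nowhere on a scale of numbers: its value in this assay is a limit of the assay, not a measured concentration. The value for compound 2 is likewise a limit. The value for compound 3 is also a limit. Among the compounds with values here, all that the three measured compounds share is the limit of > 40000 nM in this assay, at which 3 of the 3 values shown sit, so nothing among them orders one against another, and no step between measured compounds can be read from these data.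

The next compound, compound 4 `C#CC1=Nc2ccccc2C(C)(C)O1`, differs from compound 1 in one place: hydrogen in place of methyl on a triple-bonded carbon. The change removes a single carbon at the far end of the triple bond and leaves the rest of the core of compound 1 untouched.

Within the data shown here, with compound 1 at a limit and no measured step to lean on, the expectation for compound 4 is a step of no size beyond the scatter in this assay, in neither direction. Compound 4 is therefore expected to remain at the same limit, with an estimate of 60000 nM and a range from 20000 nM to 200000 nM. The step this estimate implies is a step that the limit leaves unreadable from compound 1 to compound 4, which is expected to be nothing beyond the scatter.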

Compound 4, half-maximal inhibitory concentration: 5610 nM
Compound 4: middle estimate off by 11-fold (1.03 log units), on the high side; measured number below the stated range.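

In this assay, within the data shown here, hydrogen in place of methyl on a triple-bonded carbon gives an at least 7.1-fold lower number from compound 1 to compound 4 (0.85 log units; beyond the scatter) and so provides the first readable step. It shows that this position is not indifferent to the change: the swap from prop-1-yn-1-yl to ethynyl, with the rest of the core of compound 1 untouched, is enough to bring compound 4 off the value shared by the other compounds, which until now offered nothing to compare: the limit of > 40000 nM in this assay, at which 3 of the 4 values shown sit. The value of compound 1 is a limit, so the step has a known minimum but no known full size, and a single pair says nothing about any other group at this position.

The compounds shown leave open whether a longer chain, a hydroxymethyl group or an amine on the triple-bonded carbon would hold the number seen for compound 4, lower it further or return it to the limit. Among these compounds, they also leave open whether the triple bond itself matters, and what the same swap would do on a core other than the one shared by compound 1 and compound 4.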